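Swapping the Tail on a Shared Core

The compounds below may be only part of what the source reports. "The series", "measured", "known", "first", "only" and "open" are said of these compounds alone.

Of the compounds shown here, two built on the same core have been tested so far. Compound 1 `CN(C)C(=O)c1cc2cnc(Nc3ccc(S(=O)(=O)NCCCN=C=S)cc3)nc2n1C1CCCC1` and compound 2 `CN(C)C(=O)c1cc2cnc(Nc3ccc(C(=O)NCCCCCN=C=S)cc3F)nc2n1C1CCCC1` share that core and carry a chain ending in an isothiocyanate on the aromatic ring; they differ in the chain and in a fluorine on the ring. In a functional assay on NCI-H1299 cells (Homo sapiens) for inhibition, read by CCK-8 assay, with a stated time of 72 h, tested at 1 uM (a higher number here means a stronger effect of the compound at the concentration tested, a lower number a weaker effect), compound 1 gives 41.3%, and compound 2 gives 36.1%; the gap between the two lies within the usual scatter, so on the numbers shown compound 1 cannot be set apart from compound 2.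

Compound 3 `CN(C)C(=O)c1cc2cnc(Nc3ccc(NC(=O)CCCCCCN=C=S)cc3)nc2n1C1CCCC1` is the next compound, not yet measured. Compared with compound 1 the change is a group of 12 heavy atoms (8 carbon, 2 nitrogen, 1 oxygen, 1 sulfur; no ring) in place of a group of 10 heavy atoms (4 carbon, 2 nitrogen, 2 oxygen, 2 sulfur; no ring), on an aromatic carbon. Among the compounds with values here, no pair of measured compounds shows what such a change does, so nothing can be read from the data about its size or direction.

Given that the two measured compounds sit within the scatter of each other, the step from compound 1 to compound 3 is expected to be small, a number 3.3 percentage points lower from compound 1 to compound 3 (within the scatter), and not beyond the scatter. Compound 3 is expected to give 38% in this assay, within a range from 20% to 56%.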

Compound 3, a percentage reported as inhibition, at one concentration (the size of the read-out at that concentration, not a potency): 50.9%
Compound 3: the middle estimate sits 12.9 percentage points below what was measured; the range from low to high includes it.
By their numbers in this assay, from the lowest: compounds 2, 1 and 3 (each within the scatter of the next, the first and the last beyond it).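

In this assay, exchanging the group of 10 heavy atoms for the group of 12 heavy atoms, on an aromatic carbon para to a large group, gives a number 9.6 percentage points higher from compound 1 to compound 3 (within the scatter). Within the data shown here, this is the only measured pair that differs in one place, and it shows that this particular exchange does not set the two compounds apart, even though the entering group has more carbon, one oxygen and one sulfur fewer, one double bond fewer and one hydrogen-bond acceptor fewer. No measurement available here explains why the read-out stays within the scatter across this exchange.

The two groups differ in several features at once, so this single step cannot show which feature, if any, matters, and it says nothing about how a different group would behave at this position. Still open, going by these compounds, are a longer chain ending in the same isothiocyanate, and a chain of the same length ending in an amine or a carboxylic acid instead, either of which could show whether the read-out moves beyond the scatter.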